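Swapping the amino group on a short-lived compound

A few compounds are considered here, and "the series" means these few. Any claim that something is new, unique, unknown or untested is made for them only; others in the source may bear on it.

Among the measured compounds shown here, in an in vitro ADME assay on microsomes (Rattus norvegicus) for metabolic stability (on this read-out higher numbers stand for a longer-lived compound and lower numbers for a shorter-lived compound), compound 2 (`CCCN(CC1CC1)c1nc(CC)c(-c2ccc(Cl)cc2Cl)nc1CC`) gives 0.07 h, the only true number so far. Compound 1 (`CCc1nc(N(CC2CC2)CC2CC2)c(CC)nc1-c1ccc(Cl)cc1Cl`) gives < 0.0167 h, which is a limit of the assay. For the measured compounds named here, the single measured step, an at least 4.1-fold higher number from compound 1 to compound 2 (0.62 log units; beyond the scatter), is at least modest, but its size rests on (the limit of < 0.0167 h in this assay, at which 1 of the 2 values shown sits), and it alters only part of the amino group. Compound 3 (`CCc1nc(-c2ccc(Cl)cc2Cl)c(CC)nc1NC(CC)CC`) replaces that whole group: (pentan-3-yl)amino in place of (cyclopropylmethyl)(propyl)amino on an aromatic carbon. With so loose a guide, only a small step is expected, a 1.4-fold higher number from compound 2 to compound 3 (0.15 log units; within the scatter). For compound 3 the estimated half-life is 0.1 h, with a range of 0.03 h to 0.35 h.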

Compound 3, half-life: 0.07 h
Compound 3: middle estimate off by 1.4-fold (0.15 log units), on the high side; low and high end bracket the measured number.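

In this assay, the position tolerates a complete exchange of its amino group: with (pentan-3-yl)amino in place of (cyclopropylmethyl)(propyl)amino, the read-out shows no change at the digits printed from compound 2 to compound 3 (within the scatter). Losing the three-membered ring and gaining a hydrogen-bond donor therefore leaves no trace in this read-out. The change from bis(cyclopropylmethyl)amino gives an at least 4.1-fold higher number from compound 1 to compound 3 (0.62 log units; beyond the scatter), but its true size stays unknown: the limit of < 0.0167 h in this assay, at which 1 of the 3 values shown sits.

On these data alone, whether an unsubstituted amino group or a morpholine here would lift the half-life remains open. So does whether a change elsewhere on the shared core, such as replacing an ethyl group with a methyl group, would do more than this exchange.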